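The source may report more compounds than this note shows. Statements on the series, on what has been measured and on what is new or still open speak of the compounds shown alone.

In a functional assay (Platelet, plasma) for inhibition, with Homo sapiens as the target (a higher number here means a weaker inhibitor, a lower number a stronger inhibitor), compound 1 `CC(c1ccccc1)S(=O)(=O)NC(=O)C1CCN(c2nc3c(cc2C#N)C(=O)OC3)CC1` gives 4160 nM and compound 2 `N#Cc1cc2c(nc1N1CCC(C(=O)NS(=O)(=O)Cc3ccc(C(F)(F)F)cc3)CC1)COC2=O` gives 15900 nM as the higher of the two numbers. Compound 3 `N#Cc1cc2c(nc1N1CCC(C(=O)NS(=O)(=O)Cc3ccc(F)cc3)CC1)COC2=O` carries fluoro in place of trifluoromethyl on an aromatic carbon, para to a large group (fluoro in place of trifluoromethyl on an aromatic carbon). Going by the values given here, the one measured step, which falls on the same sulfonyl substituent, is a 3.8-fold higher number from compound 1 to compound 2 (0.58 log units; beyond the scatter) and it offers only a modest guide, so a move of similar modest size towards a lower number is expected. The expected change is a 2.0-fold lower number from compound 2 to compound 3 (0.30 log units; within the scatter) on this thin evidence. Compound 3 is estimated at 8000 nM with a range from 3000 nM to 20000 nM as its likely span.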

Compound 3, half-maximal inhibitory concentration: 3500 nM
Compound 3: the middle estimate sits 2.3-fold (0.36 log units) above what was measured; the measured number falls inside the stated range.
By their numbers in this assay, from the lowest: compounds 3 and 1 (each within the scatter of the next); then compound 2.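

In this assay, the change at this aromatic carbon alone moves the number, with fluoro in place of trifluoromethyl giving a 4.5-fold lower number from compound 2 to compound 3 (0.66 log units; beyond the scatter). The 4-fluorobenzyl group and the 1-phenylethyl group on the sulfonyl sulfur cannot be told apart, at a 1.2-fold lower number from compound 1 to compound 3 (0.08 log units; within the scatter), so among these compounds the higher number goes with the trifluoromethyl group and not with the benzyl group as such. Nothing available explains why the number shifts. As far as these compounds go, whether a methoxy group or a chlorine atom at this carbon would track with fluoro or with trifluoromethyl remains open.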